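Ester to carbamate: a hexadecyl chain with a new ring

The compounds below may be only part of what the source reports. "The series", "measured", "known", "first", "only" and "open" are said of these compounds alone.

Of the compounds shown here, three have been tested in an assay on HEK293 cells for inhibition of N-acylethanolamine-hydrolyzing acid amidase (Homo sapiens), read by scintillation counting, tested at 50 uM; a higher number here means more inhibition at the concentration tested (going by the name of the read-out), a lower number less inhibition. Compound 1 `CCCCCCCCCCCCCCCC(=O)NC1CCN(Cc2ccccc2)CC1` is reported as "not active" (no number reported), without a number. Compound 2 `CCCCCCCCCCCCCCCCNC(=O)C1CCCC1` gives 8%, and compound 3 `CCCCCCCCCCCCCCCCOC(=O)C1CCCC1` gives 17%. Going by the values given here, the only measured step with a single change, a number 9 percentage points higher from compound 2 to compound 3 (within the scatter), stays within the scatter, so the numbers of compound 2 and compound 3 cannot be told apart.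

Compound 4 `CCCCCCCCCCCCCCCCOC(=O)NC1CCCCC1` has not yet been measured. It differs from compound 3 as follows: cyclohexylamino in place of cyclopentyl on a carbonyl carbon. Among the compounds with values here, no measured step touches the ring or adds an amino group at this position, so nothing measured bears directly on this change; the one step known, the amino-to-oxy exchange on the chain, was small. The estimated step of a number 2 percentage points lower from compound 3 to compound 4 (within the scatter) is therefore expected to stay within the scatter. Compound 4 is estimated at 15%, with a range from 0% to 35%.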

Compound 4, a percentage reported as inhibition, at one concentration (the size of the read-out at that concentration, not a potency): "not active" (no number reported)
Compound 4: no number reported; there is nothing to compare the estimate with.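

In this assay, going by these compounds alone, compound 4 gives "not active" (no number reported) and so, with no number, no step from compound 3 to compound 4 can be read. Nothing shown accounts for this result. Open remains how much cyclohexylamino in place of cyclopentyl alters inhibition.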